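The source may hold more compounds than are shown below. What is called first, only, known or untested is meant among the compounds shown, and "the series" means these compounds.

Measured compounds:

compound 1 `COc1cccc(-c2ccc3oc(N4Cc5ccccc5C4)nc3c2)c1` — 28 nM
compound 2 `COCc1ccc(-c2ccc3oc(N4Cc5ccccc5C4)nc3c2)cc1` — 10 nM
compound 3 `COc1cc(-c2ccc3oc(N4Cc5ccccc5C4)nc3c2)ccn1` — 10 nM

All three share the same core and differ only in the aromatic group attached to it, and all three were tested in an assay on HEK293 cells for inhibition of Fatty-acid amide hydrolase 1 (Homo sapiens), read by fluorescence; on this read-out lower numbers stand for stronger inhibition and higher numbers for weaker inhibition. Compound 3 gives 10 nM, which is level with compound 2 at the digits shown; together they have the lowest numbers of the three. The furthest from compound 3 is compound 1, and the step of a 2.8-fold lower number from compound 1 to compound 3 (0.45 log units; beyond the scatter) was modest but beyond the scatter. The step of a 2.8-fold lower number from compound 1 to compound 2 (0.45 log units; beyond the scatter) was of the same size, while no change at the digits printed from compound 2 to compound 3 (within the scatter) stayed within the scatter.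

Compound 4 `c1ccc2c(c1)CN(c1nc3cc(-c4ccc5nccn5c4)ccc3o1)C2` changes the same position once more: a group of 9 heavy atoms (7 carbon, 2 nitrogen; one five-membered aromatic ring with 2 hetero atoms, one six-membered aromatic ring with 1 hetero atom) in place of a group of 8 heavy atoms (6 carbon, 1 nitrogen, 1 oxygen; one six-membered aromatic ring with 1 hetero atom), on an aromatic carbon. The relevant experience is that exchanging one aromatic group for another at this carbon has so far moved the number modestly at most, and the last such exchange, from compound 2 to compound 3, did not move it beyond the scatter. A step of similar size, or none beyond the scatter, is therefore expected in this assay for compound 4.

Compound 4 is estimated at 12 nM, with a range from 4 nM to 40 nM. This estimate means an expected step of a 1.2-fold higher number from compound 3 to compound 4 (0.08 log units; within the scatter).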

Compound 4, half-maximal inhibitory concentration: 14 nM
The estimate for compound 4 lay 1.2-fold (0.07 log units) below the measured number; measured number inside the range.
By their numbers in this assay, from the lowest: compounds 2, 3, 4 and 1 (each within the scatter of the next, the first and the last beyond it).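

On this aromatic carbon, a group with a five-membered and a six-membered aromatic ring can take the place of a single aromatic ring without a change that can be told from the scatter in this assay: the step is a 1.4-fold higher number from compound 3 to compound 4 (0.15 log units; within the scatter) against the 2-methoxypyridin-4-yl group, and a 1.4-fold higher number from compound 2 to compound 4 (0.15 log units; within the scatter) against the 4-(methoxymethyl)phenyl group. Compound 1 had stood apart from the other two earlier compounds, but the step of a 2.0-fold lower number from compound 1 to compound 4 (0.30 log units; within the scatter) also lies within the scatter, so compound 4 cannot be separated from any of the three, and this larger two-ring group adds no clear gain or loss at this position. No measurement is available here that could explain why the two-ring group and the single rings give such similar numbers.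

The compounds shown leave open whether this position accepts something other than an aromatic ring with neutral substituents, such as a carboxylic acid or a dimethylamino group on the ring, or a saturated morpholine ring attached directly to the carbon. They also leave open how far the number depends on the rest of the shared core, which stays the same throughout.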